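A few compounds are considered here, and "the series" means these few. Any claim that something is new, unique, unknown or untested is made for them only; others in the source may bear on it.

Compound 2 `O=C1C(Nc2cccc(Cl)c2)=CC(=O)c2c1nc1n2[C@H]2OC[C@@H](O)[C@H]2OC1` carries a 3-chlorophenyl group on the amine nitrogen of a core it shares with two measured partners, compound 1 `Cc1ccc(NC2=CC(=O)c3nc4n(c3C2=O)[C@H]2OC[C@@H](O)[C@H]2OC4)cc1C` and compound 3 `O=C1C=C(Nc2ccc(C(F)(F)F)cc2)C(=O)c2c1nc1n2[C@H]2OC[C@@H](O)[C@H]2OC1`. In a functional assay on MGC-803 cells (Homo sapiens) for inhibition, read by sulforhodamine B assay (a lower number here means a stronger inhibitor, a higher number a weaker inhibitor), compound 2 gives 1530 nM. Compound 1 gives 860 nM and compound 3 gives 2820 nM; both numbers lie within the scatter of that of compound 2, so the three compounds cannot be separated on these data.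

Compound 4 `O=C1C(Nc2ccc(I)cc2)=CC(=O)c2c1nc1n2[C@H]2OC[C@@H](O)[C@H]2OC1` differs from compound 2 in one place: 4-iodophenyl in place of 3-chlorophenyl on an amine nitrogen. Among the compounds with values here, the only single-point step that has been measured, a 3.3-fold higher number from compound 1 to compound 3 (0.52 log units; beyond the scatter), concerns a different pair of groups on the same amine nitrogen and was modest. Nothing measured speaks directly to a halogen moving from 3-chlorophenyl to 4-iodophenyl. Compound 4 is therefore expected to behave much like compound 2, with the estimate for compound 4 in this assay put at 1500 nM, between 600 nM and 4000 nM. The expected step of a 1.0-fold lower number from compound 2 to compound 4 (0.01 log units; within the scatter) is thus one that need not reach beyond the scatter.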

Compound 4, half-maximal inhibitory concentration: 2150 nM
For compound 4 the middle estimate is 1.4-fold (0.16 log units) below the measured one; measured number inside the range.
By their numbers in this assay, from the lowest: compounds 1, 2, 4 and 3 (each within the scatter of the next, the first and the last beyond it).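

In this assay the change to 4-iodophenyl in place of 3-chlorophenyl on the amine nitrogen gives a 1.4-fold higher number from compound 2 to compound 4 (0.15 log units; within the scatter) and so stays inside the normal spread of repeat measurements. Within the data shown here, this is the first measured step between two halogen-bearing phenyl groups at this position, and it shows that swapping chlorine for iodine while also changing the printed ring position produces no readable shift in this cell assay. Because both features change together, the pair cannot show whether each matters alone, and no measurement at hand offers an explanation of the result.

A 4-chlorophenyl group would separate the identity of the halogen from its ring position. Also open, on these data alone, is what a carboxylic acid on the phenyl ring, or a simple alkyl chain replacing that ring, would do.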